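Swapping Phenyl for Piperidine on the Sulfonyl Group

The compounds below may be only part of what the source reports. "The series", "measured", "known", "first", "only" and "open" are said of these compounds alone.

Of the compounds shown here, two have been measured in a functional assay on HEK293 cells for agonist activity at growth hormone secretagogue receptor type 1 (Homo sapiens), read by HTRF and inositol phosphate accumulation, with a stated time of 90 min, in the presence of a further agent that is not named here; on this read-out higher numbers stand for larger maximal responses and lower numbers for smaller maximal responses. Compound 1 `Cc1ccc2[nH]c(C(=O)N[C@H]3CN(S(=O)(=O)c4ccnc(C)c4)C[C@@H]3C(=O)NCCN(C)C)cc2c1` gives 91%. Compound 2 `Cc1ccc2[nH]c(C(=O)N[C@H]3CCN(S(=O)(=O)c4ccccc4)C[C@@H]3C(=O)NCCN(C)C)cc2c1` gives 98% in this assay; its number is the larger of the two shown, yet the gap to compound 1 is within the scatter, so the two are not told apart. Compound 3 `Cc1ccc2[nH]c(C(=O)N[C@H]3CCN(S(=O)(=O)N4CCCCC4)C[C@@H]3C(=O)NCCN(C)C)cc2c1` has not been measured; it differs from compound 2 by piperidin-1-yl in place of phenyl on a sulfonyl sulfur. Among the measured compounds shown here, no measured pair shows this change, so nothing anchors the forecast. A small step is expected, a number 6 percentage points lower from compound 2 to compound 3 (within the scatter), not beyond the scatter. Compound 3 is estimated at 92%, between 75% and 105%.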

Compound 3, largest response reached (Emax), in percent of the reference or control that the assay uses: 105%
Compound 3: middle estimate off by 13 percentage points, on the low side, within the range that was stated.
By their numbers in this assay, from the lowest: compounds 1, 2 and 3 (each within the scatter of the next, the first and the last beyond it).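

In this assay, putting piperidin-1-yl in place of phenyl on the sulfonyl sulfur gives a number 7 percentage points higher from compound 2 to compound 3 (within the scatter). The two groups therefore cannot be told apart here, so an aromatic ring of carbon only is not required on this sulfur for a large maximal response. Nothing available explains this outcome. Going by these compounds, it remains open whether a ring is needed here at all, as dimethylamino would test, and whether morpholin-4-yl, with its ring oxygen, would give a similar response.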